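The source may report more compounds than this note shows. Statements on the series, on what has been measured and on what is new or still open speak of the compounds shown alone.

Measured so far:
compound 1 `COC(=O)[C@H](CCSC)NC(=O)c1cccc(CN(Cc2ccc(C#N)cc2)Cc2c[nH]cn2)c1`
compound 2 `COC(=O)[C@H](CCSC)NC(=O)c1cccc(CNCc2cncn2Cc2ccc(C#N)cc2)c1`
compound 3 `CCCCN(Cc1cccc(C(=O)N[C@@H](CCSC)C(=O)OC)c1)Cc1cncn1Cc1ccc(C#N)cc1`

In a functional assay on Rat1 cells (Rattus norvegicus) for inhibition, read by colony formation (on this read-out lower numbers stand for stronger inhibition of growth and higher numbers for weaker inhibition of growth), compound 1 gives only a limit, > 10000 nM. Compound 2 also gives only a limit, > 10000 nM. Compound 3 gives only a limit, > 10000 nM. Compound 3 thus stands at the limit of > 10000 nM in this assay, at which 3 of the 3 values shown sit, and has no number of its own. Going by the values given here, the one measured step, a step that the two limits leave unreadable from compound 2 to compound 3, cannot be read because both of its ends sit at the limit of > 10000 nM in this assay, at which 3 of the 3 values shown sit. Compound 4 `COC(=O)[C@H](CCSC)NC(=O)c1cccc(CN(Cc2ccc(C#N)cc2)Cc2cncn2Cc2ccc(C#N)cc2)c1` differs from compound 3 by 4-cyanophenyl in place of propyl on a saturated chain carbon bound to an amine nitrogen. Among the compounds with values here, no measured step bears on this change, so no direction can be drawn from the series. Compound 4 is therefore expected to remain near the limit, with an estimated step that the limit leaves unreadable from compound 3 to compound 4, not beyond the scatter. The estimate for compound 4 is 15000 nM, ranging from 4000 nM to 60000 nM.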

Compound 4, minimum inhibitory concentration: > 10000 nM
Compound 4 was reported as a limit (the forecaster's own chance of this, stated with the estimate: 80%); the middle value does not contradict the limit.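

In this assay compound 4 gives only a limit, > 10000 nM. The steps to compound 4 from compound 2 and compound 3 cannot be read: the limit of > 10000 nM in this assay, at which 4 of the 4 values shown sit. The compounds shown leave open which change to the shared core, if any, would give a value that is not a limit in this assay.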